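The source may hold more compounds than are shown below. What is called first, only, known or untested is meant among the compounds shown, and "the series" means these compounds.

Measured in a functional assay on the whole organism for inhibition, with Cavia porcellus as the target; on this read-out lower numbers stand for an effect already at smaller amounts and higher numbers for an effect only at larger amounts of compound:
- compound 1 `COc1ccccc1OCC1SCCN1C(=O)C[S+](C)[O-]`: 25 mg/kg
- compound 2 `COc1ccccc1OCC1SCCN1C(=O)CNC(C)=O`: 40 mg/kg
- compound 3 `COc1ccccc1OCC1SCCN1C(C)=O`: 46 mg/kg

Compound 3, at 46 mg/kg, lies within the scatter of both other compounds. Compound 4 `CCCC(=O)CC(=O)N1CCSC1COc1ccccc1OC` differs from it by propylcarbonyl in place of hydrogen on a saturated chain carbon bound to a carbonyl carbon. Two measured steps change this same carbon: a 1.2-fold higher number from compound 2 to compound 3 (0.06 log units; within the scatter) and a 1.8-fold higher number from compound 1 to compound 3 (0.26 log units; within the scatter). Among the compounds with values here, both stay within the scatter, although no measured compound carries propylcarbonyl. No step beyond the scatter is therefore expected in this assay, and no direction can be firmly expected. The expected change is a 1.3-fold lower number from compound 3 to compound 4 (0.12 log units; within the scatter). For compound 4 the estimated value is 35 mg/kg, with an expected range of 17 mg/kg to 70 mg/kg.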

Compound 4, dose for half-maximal effect: 42 mg/kg
Compound 4: middle estimate off by 1.2-fold (0.08 log units), on the low side, and the stated range covers the measured number.
By their numbers in this assay, from the lowest: compounds 1, 2, 4 and 3 (each within the scatter of the next).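

In this assay the saturated chain carbon bound to a carbonyl carbon also accepts propylcarbonyl, and the outcome is a 1.1-fold lower number from compound 3 to compound 4 (0.04 log units; within the scatter) and so within the scatter. The comparisons with the other two groups on this carbon also stay within the scatter, giving a 1.1-fold higher number from compound 2 to compound 4 (0.02 log units; within the scatter) and a 1.7-fold higher number from compound 1 to compound 4 (0.23 log units; within the scatter), so hydrogen and all three substituents shown remain indistinguishable here. Nothing at hand explains this result. From the compounds shown here alone, it remains open whether an amine or a carboxylic acid on this carbon would move the number beyond the scatter.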